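The source may report more compounds than this note shows. Statements on the series, on what has been measured and on what is new or still open speak of the compounds shown alone.

Of the compounds shown here, three have been measured in a functional assay on CHO cells for antagonist activity at prostaglandin E2 receptor EP3 subtype (Homo sapiens), read by cAMP accumulation; on this read-out higher numbers stand for weaker inhibition and lower numbers for stronger inhibition. Compound 1 `CC(C)C(O)(C(=O)O)c1ccc(-c2ccc3ccccc3c2)[nH]c1=O` gives 1580 nM in this assay. Compound 2 `CC(C)C(c1ncco1)c1ccc(-c2ccc3cccc(F)c3c2)[nH]c1=O` gives 64 nM, the lowest number of the three. Compound 3 `CCn1ncc2c(F)cc(-c3ccc(C(CC)(CC)c4nncn4C)c(=O)[nH]3)cc21` gives 120 nM; the gap between compound 3 and compound 2 lies within the usual scatter of this measurement, so the two cannot be ranked, whereas the gap between compound 1 and compound 2 lies well beyond it.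

Compound 4 `CC(C)C(Nc1nccs1)c1ccc(-c2ccc3cccc(F)c3c2)[nH]c1=O` has not yet been measured. It differs from compound 2 in one place: (1,3-thiazol-2-yl)amino in place of 1,3-oxazol-2-yl on a saturated chain carbon bound to an aromatic carbon and a saturated chain carbon. The entering group keeps a five-membered aromatic ring with two hetero atoms, but the ring is now attached through an amino link that carries one hydrogen-bond donor, and the ring itself contains sulfur in place of oxygen. Among the measured compounds shown here, no pair of measured compounds shows the effect of this change, so its size is unknown from the data at hand. Since compound 2 gives 64 nM and its measured neighbours sit close by or above it, the expectation is a small step, most likely towards a somewhat higher number, and possibly none beyond the scatter. The estimated step is a 2.0-fold higher number from compound 2 to compound 4 (0.31 log units; beyond the scatter). Compound 4 is therefore expected to give about 130 nM in this assay, with a range from 35 nM to 500 nM.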

Compound 4, half-maximal inhibitory concentration: 10 nM
The estimate for compound 4 lay 13-fold (1.11 log units) above the measured number; the measured number lies below the stated range.
By their numbers in this assay, from the lowest: compound 4; then compounds 2 and 3 (each within the scatter of the next); then compound 1.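

In this assay, the group on the saturated chain carbon bound to an aromatic carbon and a saturated chain carbon clearly matters: with the rest of the molecule unchanged, (1,3-thiazol-2-yl)amino in place of 1,3-oxazol-2-yl gives a 6.4-fold lower number from compound 2 to compound 4 (0.81 log units; beyond the scatter), a change towards stronger inhibition. Among the compounds shown here, this is the first direct reading at this position, since the earlier compounds differ from one another in more than one place and could not show the effect of any single group. Nothing measured here explains why the number falls.

The change alters two things at once, replacing the oxygen of the ring with sulfur and adding an amino link that carries a hydrogen-bond donor, so the compounds shown cannot tell which of the two accounts for the step. A 1,3-oxazol-2-yl ring joined through the same amino link, or a 1,3-thiazol-2-yl ring bound directly to the chain carbon, would separate the two, while a simple methylamino group would show how much of the ring is needed at all.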